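Methyl on the Pyrrole Nitrogen of Compound 2

The compounds below may be only part of what the source reports. "The series", "measured", "known", "first", "only" and "open" are said of these compounds alone.

In a functional assay on the whole organism (strain Wistar Albino) for inhibition, with Rattus norvegicus as the target, read by paw edema, with a stated time of 2 h, at a dose of 20 mg/kg (a higher number here means more inhibition at the dose given (going by the name of the read-out), a lower number less inhibition), compound 1 `Cc1occc1-c1nnc2n1NC(c1ccco1)S2` gives 21.6%, and compound 2 `Cc1occc1-c1nnc2n1NC(c1ccc[nH]1)S2` gives 18.2%, the lowest of the two numbers available, though its gap to compound 1 lies within the scatter. Compound 3 `Cc1occc1-c1nnc2n1NC(c1cccn1C)S2` differs from compound 2 by methyl in place of hydrogen on an aromatic nitrogen. Going by the values given here, the only measured step, a number 3.4 percentage points lower from compound 1 to compound 2 (within the scatter), exchanged one five-membered aromatic ring for another on the saturated ring carbon and stayed within the scatter. On that basis compound 3 is expected to show a number 0.8 percentage points higher from compound 2 to compound 3 (within the scatter), nothing beyond the scatter. Compound 3 is therefore estimated at 19%, between 8% and 30%.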

Compound 3, a percentage reported as inhibition, in the whole organism at one dose (the size of the read-out at that dose, not a potency): 18.9%
Compound 3: middle estimate off by 0.1 percentage points, on the high side, within the range that was stated.
By their numbers in this assay, from the lowest: compounds 2, 3 and 1 (each within the scatter of the next).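

In this assay, methyl on the aromatic nitrogen gives a number 0.7 percentage points higher from compound 2 to compound 3 (within the scatter) and so leaves the reading unmoved: this nitrogen can carry hydrogen or methyl without a difference beyond the scatter. The 1-methyl-1H-pyrrol-2-yl group also stays level with the furan-2-yl of compound 1, with a number 2.7 percentage points lower from compound 1 to compound 3 (within the scatter) on that exchange. No evidence is available to explain these readings. Still open, going by these compounds, is whether a longer chain such as butyl or a benzyl group on this nitrogen, or a carboxylic acid on the pyrrole ring, would move the number beyond the scatter.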